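A few compounds are considered here, and "the series" means these few. Any claim that something is new, unique, unknown or untested is made for them only; others in the source may bear on it.

In a functional assay on MOLT-4F cells (Homo sapiens) for antiproliferative activity (on this read-out higher numbers stand for weaker inhibition of growth and lower numbers for stronger inhibition of growth), compound 1 `COCCCCCCCCCCCCCCC/C=C1\CC(CO)(COC(=O)C(C)(C)C)OC1=O` gives 0.498 ug/mL. Compound 3 `CC(C)(C)C(=O)OCCCCCCCCCCCCCCC/C=C1\CC(CO)(COC(=O)C(C)(C)C)OC1=O` gives 0.605 ug/mL, and a 1.2-fold higher number from compound 1 to compound 3 (0.08 log units; within the scatter) leaves the two together at the low end of the numbers shown. Compound 2 `COC(=O)CCCCCCCCCCCCCC/C=C1\CC(CO)(COC(=O)C(C)(C)C)OC1=O` gives > 10 ug/mL, which is a limit of the assay and not a number. The measured steps to and from it are large: an at least 20-fold higher number from compound 1 to compound 2 (1.30 log units; beyond the scatter), and an at least 16-fold lower number from compound 2 to compound 3 (1.21 log units; beyond the scatter).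

Compound 4 `CC(=O)NCCCCCCCCCCCCCCC/C=C1\CC(CO)(COC(=O)C(C)(C)C)OC1=O` departs from compound 1 by one change: acetamido in place of methoxy on a saturated chain carbon, ten or more bonds along the chain from a double-bonded chain carbon. For the measured compounds named here, no measured step makes this exact change, so all three bear on it only indirectly. The step of a 1.2-fold higher number from compound 1 to compound 3 (0.08 log units; within the scatter) shows that a larger group can leave the number unchanged, while an at least 20-fold higher number from compound 1 to compound 2 (1.30 log units; beyond the scatter) shows that a change at this place on the chain can cost heavily. A moderate move to a higher number in this assay is therefore expected, with real uncertainty, as a 3.0-fold higher number from compound 1 to compound 4 (0.48 log units; beyond the scatter). For compound 4 the estimated value is 1.5 ug/mL, with an expected range from 0.3 ug/mL to 10 ug/mL.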

Compound 4, concentration for 50% growth inhibition: 6.35 ug/mL
Compound 4: the middle estimate sits 4.2-fold (0.63 log units) below what was measured; the range from low to high includes it.
By their numbers in this assay, from the lowest: compounds 1 and 3 (each within the scatter of the next); then compound 4. At a limit, above all of these: compound 2.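

In this assay, for the compounds shown here, the steps of a 13-fold higher number from compound 1 to compound 4 (1.11 log units; beyond the scatter) and a 10-fold higher number from compound 3 to compound 4 (1.02 log units; beyond the scatter) show that the end of the chain does not tolerate every replacement of methoxy, so methoxycarbonyl in compound 2 is no longer the only group here that gives a large rise in the number. Acetamido brings the amide hydrogen, absent from compounds 1 and 3, but compound 2 also lacks that hydrogen and still stands high, so its presence alone does not sort these compounds, and an at least 1.5-fold lower number from compound 2 to compound 4 (0.19 log units; that floor lies within the scatter) gives only a floor. The value of compound 2 is a limit and not a number: the limit of > 10 ug/mL in this assay, at which 1 of the 4 values shown sits.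

The compounds shown leave open how a free amine or a carboxylic acid would behave at this place. They also leave open whether a longer chain would change the effect of acetamido.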